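Phenyl removal carried over to the sulfoxide compound

The source may hold more compounds than are shown below. What is called first, only, known or untested is meant among the compounds shown, and "the series" means these compounds.

Measured so far:
- compound 1 `CCCCCCCN(CCCCCSc1cc(-c2ccccc2)c(-c2ccccc2)nn1)C(=O)Nc1ccc(F)cc1F`: 75%
- compound 2 `CCCCCCCN(CCCCCSc1ccc(-c2ccccc2)nn1)C(=O)Nc1ccc(F)cc1F`: 44%
- compound 3 `CCCCCCCN(CCCCC[S+]([O-])c1cc(-c2ccccc2)c(-c2ccccc2)nn1)C(=O)Nc1ccc(F)cc1F`: 65%

In an assay on microsomes from liver for inhibition of sterol O-acyltransferase 1 (Rattus norvegicus), tested at 50 ug/mL (on this read-out higher numbers stand for more inhibition at the one concentration tested (going by the name of the read-out) and lower numbers for less inhibition), compound 3 stands second highest of the three numbers; its nearest neighbour is compound 1, with compound 3 a number within the scatter below it, and its furthest is compound 2, well beyond the scatter below compound 3. Compound 4 `CCCCCCCN(CCCCC[S+]([O-])c1ccc(-c2ccccc2)nn1)C(=O)Nc1ccc(F)cc1F` is not yet measured. From compound 3 to compound 4 the change is hydrogen in place of phenyl on an aromatic carbon. Among the compounds with values here, one measured step bears directly on it: the same change on the sulfide pair, a number 31 percentage points lower from compound 1 to compound 2 (beyond the scatter). A drop of comparable size is therefore expected in this assay for compound 4, namely a number 31 percentage points lower from compound 3 to compound 4 (beyond the scatter). Compound 4 is accordingly estimated at 34%, within the range 15% to 55%.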

Compound 4, a percentage reported as inhibition, at one concentration (the size of the read-out at that concentration, not a potency): 55%
For compound 4 the middle estimate is 21 percentage points below the measured one; measured number inside the range.
By their numbers in this assay, from the lowest: compound 2; then compounds 4, 3 and 1 (each within the scatter of the next, the first and the last beyond it).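

In this assay, hydrogen in place of phenyl on the sulfoxide gives a number 10 percentage points lower from compound 3 to compound 4 (within the scatter), so the large step seen on the sulfide does not carry over in size. The effect of this change at this position therefore depends on the core that carries it: the same change on two cores in this assay, a number 31 percentage points lower (beyond the scatter) from compound 1 to compound 2 and a number 10 percentage points lower (within the scatter) from compound 3 to compound 4, 21 percentage points apart, beyond the scatter of two such steps

Within the data shown here, with only two pairs, this dependence rests on a single sulfide and sulfoxide comparison. Open, going by these compounds, is how a methyl group, an amine or a carboxylic acid at this position would read on either core, and how the change would read on a sulfone.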